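Cytotoxicity notes: deoxyuridine series, a pentynyl replacement

The compounds below may be only part of what the source reports. "The series", "measured", "known", "first", "only" and "open" are said of these compounds alone.

Measured so far:
- compound 1, `C=C(Cl)c1cn([C@H]2C[C@H](O)[C@@H](CO)O2)c(=O)[nH]c1=O`: 1660 nM
- compound 2, `C[C@H](O)C1CC(CCn2nnc3c(N)ncnc32)C1(C)C`: > 200000 nM
- compound 3, `CC1(C)[C@@H](CO)CC[C@@]1(C)Cn1cc(I)c(=O)[nH]c1=O`: > 200000 nM

Three compounds have numbers or limits in an ADME assay on L1210/0 cells (Mus musculus) for cytotoxicity, with a stated time of 48 h; on this read-out lower numbers stand for stronger inhibition and higher numbers for weaker inhibition. Going by the values given here, compound 1 is the only one with a measured value, 1660 nM in this assay. Compound 2 reaches only the assay limit, > 200000 nM in this assay. Compound 3 likewise stops at the limit, > 200000 nM in this assay; these two sit at the limit of > 200000 nM in this assay, at which 2 of the 3 values shown sit. Among the compounds with values here, no pair of measured compounds differs in a single place, so no measured step is available.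

Compound 4, `CCCC#Cc1cn([C@H]2C[C@H](O)[C@@H](CO)O2)c(=O)[nH]c1=O`, has not been measured. It differs from compound 1 by pent-1-yn-1-yl in place of 1-chloroethenyl on an aromatic carbon. On the shared core of compound 1 this exchange removes the halogenated alkene and introduces a longer alkyne chain. Within the data shown here, with no measured step to lean on, the expectation rests on compound 1 alone at 1660 nM: a step beyond the scatter toward weaker inhibition is expected, namely a 4.8-fold higher number from compound 1 to compound 4 (0.68 log units; beyond the scatter). For compound 4 the estimate is 8000 nM, with a range from 1500 nM to 50000 nM.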

Compound 4, half-maximal inhibitory concentration: > 200000 nM
Compound 4 ended at the assay's limit; the forecaster's own chance of this, stated with the estimate: 10%; at least 25-fold (1.39 log units) between middle value and limit.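

In this assay, going by these compounds alone, pent-1-yn-1-yl in place of 1-chloroethenyl on the aromatic carbon gives an at least 120-fold higher number from compound 1 to compound 4 (2.08 log units; beyond the scatter) and so provides the first readable step, showing that the group at this position can decide whether the shared core gives a measurable value at all. For compound 4 the entry > 200000 nM is a limit of the assay and not a number. Within the data shown here, compound 1 therefore remains the only compound with a measured value, and compound 4 joins the others at the limit: the limit of > 200000 nM in this assay, at which 3 of the 4 values shown sit.

The compounds shown do not separate the loss of the chlorine from the longer chain as the source of the step. From the compounds shown here alone, it also remains open how an ethynyl or a plain ethenyl group at the same position would read in this assay.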